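This account rests on a few compounds, and the source may have more. Where it says the series, first, only, none or still open, it means among the compounds named here.

Compound 1, `N#Cc1c(-c2cccc(F)c2)c(C#N)c(=O)n(/N=C/c2cn(-c3ccccc3)nc2-c2ccccc2)c1N`: 154 ug/mL
Compound 2, `N#Cc1c(-c2ccccc2Br)c(C#N)c(=O)n(/N=C/c2cn(-c3ccccc3)nc2-c2ccccc2)c1N`: 174 ug/mL

In an ADME assay on NIH3T3 cells (Mus musculus) for cytotoxicity, read by MTT assay (on this read-out higher numbers stand for weaker inhibition and lower numbers for stronger inhibition), compound 2 gives 174 ug/mL and compound 1 gives 154 ug/mL; the two lie within the usual scatter of each other, as the step of a 1.1-fold higher number from compound 1 to compound 2 (0.05 log units; within the scatter) shows. Compound 3, `N#Cc1c(-c2ccc(C(F)(F)F)cc2)c(C#N)c(=O)n(/N=C/c2cn(-c3ccccc3)nc2-c2ccccc2)c1N`, differs from compound 2 by 4-(trifluoromethyl)phenyl in place of 2-bromophenyl on an aromatic carbon. Among the compounds with values here, the only measured step, a 1.1-fold higher number from compound 1 to compound 2 (0.05 log units; within the scatter), exchanged one substituted phenyl for another at this same position and stayed within the scatter, so for compound 3 no step beyond the scatter is expected, giving a 1.1-fold lower number from compound 2 to compound 3 (0.04 log units; within the scatter). The estimate for compound 3 is 160 ug/mL, with a range from 80 ug/mL to 320 ug/mL.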

Compound 3, half-maximal inhibitory concentration: > 200 ug/mL
Compound 3 ended at the assay's limit; the forecaster's own chance of this, stated with the estimate: 10%; middle value at least 1.2-fold (0.09 log units) from the limit.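

In this assay the entry for compound 3 is a limit of the assay and not a number: the limit of > 200 ug/mL in this assay, at which 1 of the 3 values shown sits. The change therefore gives only floors, an at least 1.1-fold higher number from compound 2 to compound 3 (0.06 log units; that floor lies within the scatter) and an at least 1.2-fold higher number from compound 1 to compound 3 (0.11 log units; that floor lies within the scatter), so a 4-(trifluoromethyl)phenyl group at this position may or may not differ beyond the scatter from the other two substituted phenyl groups.

On these data alone, the true number for compound 3 stays open. So does whether an amine or a carboxylic acid on this phenyl ring, or a longer chain in its place, would shift the number beyond the scatter.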